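Alkyl and thioether replacements for fluoro in an acylguanidine series

This account rests on a few compounds, and the source may have more. Where it says the series, first, only, none or still open, it means among the compounds named here.

Measured so far in a functional assay for inhibition of sodium/hydrogen exchanger (Oryctolagus cuniculus); on this read-out lower numbers stand for stronger inhibition and higher numbers for weaker inhibition:
- compound 1 `Cc1cc(F)c(S(C)(=O)=O)cc1C(=O)N=C(N)N`: 44 nM
- compound 2 `Cc1cc(C)c(S(C)(=O)=O)cc1C(=O)N=C(N)N`: 11 nM
- compound 3 `CCC(C)c1cc(C)c(C(=O)N=C(N)N)cc1S(C)(=O)=O`: 8 nM

Compound 1 gives the highest number of the three in this assay. Its nearest neighbour is compound 2, reached by a 4.0-fold lower number from compound 1 to compound 2 (0.60 log units; beyond the scatter); further away lies compound 3, reached by a 5.5-fold lower number from compound 1 to compound 3 (0.74 log units; beyond the scatter). Between compound 2 and compound 3 the step is a 1.4-fold lower number from compound 2 to compound 3 (0.14 log units; within the scatter), so the two carbon chains cannot be ranked against each other.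

Compound 4 `CCCSc1cc(C)c(C(=O)N=C(N)N)cc1S(C)(=O)=O` has not yet been measured. It differs from compound 1 by propylsulfanyl in place of fluoro on an aromatic carbon, the change sitting at the same aromatic carbon where methyl and sec-butyl replaced fluoro in compound 2 and compound 3.

Both measured steps away from compound 1 bear on this change: each replaces fluoro with a carbon-based group at that position and each lowers the number in this assay by a modest, scatter-exceeding amount. The propylsulfanyl chain, like sec-butyl, is a multi-atom group, so a step of comparable size is expected for compound 4, in the same direction, that is a 4.4-fold lower number from compound 1 to compound 4 (0.64 log units; beyond the scatter).

Compound 4 is therefore estimated at 10 nM in this assay, with a range from 4 nM to 25 nM.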

Compound 4, half-maximal inhibitory concentration: 6.8 nM
The estimate for compound 4 lay 1.5-fold (0.17 log units) above the measured number; the range from low to high includes it.
By their numbers in this assay, from the lowest: compounds 4, 3 and 2 (each within the scatter of the next); then compound 1.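

In this assay, the replacement of fluoro no longer rests on carbon-linked groups alone: propylsulfanyl, attached through sulfur, gives a 6.5-fold lower number from compound 1 to compound 4 (0.81 log units; beyond the scatter), so a lower number than that of compound 1 has now been seen with methyl, sec-butyl and propylsulfanyl at this aromatic carbon. The comparisons among the replacements give a 1.2-fold lower number from compound 3 to compound 4 (0.07 log units; within the scatter) and a 1.6-fold lower number from compound 2 to compound 4 (0.21 log units; within the scatter), so propylsulfanyl cannot be ranked against either carbon-linked group, and across these three compounds, going from methyl with 1 heavy atom to propylsulfanyl with 4 heavy atoms brings no change that can be told from the scatter. No measurement in hand accounts for the difference from fluoro or for the flatness among the three replacements.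

On these data alone, whether the linking atom has any bearing of its own remains open, and a propoxy chain at this carbon, set against propylsulfanyl, would address that directly. How far this flat stretch extends is also unsettled, and a longer chain such as octylsulfanyl, a dimethylamino group or a carboxylic acid at the same carbon would test its limits.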